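A few compounds are considered here, and "the series" means these few. Any claim that something is new, unique, unknown or untested is made for them only; others in the source may bear on it.

Measured so far:
compound 1 `Nc1nc(NCc2ccc(F)cc2)nc(-c2ccccc2CO)n1` with 3.97
compound 2 `Nc1nc(NCc2ccc(C(F)(F)F)cc2)nc(-c2ccccc2CO)n1` with 5.03
compound 3 `Nc1nc(NCc2ccc(OC3CC3)cc2)nc(-c2ccccc2CO)n1` with 5.07

In a functional assay on cells for positive allosteric modulation of G-protein coupled receptor 68 (Homo sapiens), read by a luciferase reporter and cAMP accumulation, with a stated time of 30 min, at pH 6.8 and pH 8.3, in the presence of a further agent that is not named here (on this read-out higher numbers stand for higher potency (the scale is a negative logarithm) and lower numbers for lower potency), compound 1 stands lowest of the three. The step of a number 1.06 log units higher from compound 1 to compound 2 (beyond the scatter) and the step of a number 1.10 log units higher from compound 1 to compound 3 (beyond the scatter) are both large, while the step of a number 0.04 log units higher from compound 2 to compound 3 (within the scatter) is within the scatter. All three measured steps change the group on the other aromatic ring of the shared core, the one carrying the benzylamine.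

Compound 4 `Nc1nc(NCc2ccc(F)cc2)nc(-c2c(F)cccc2CO)n1` differs from compound 1 by fluoro in place of hydrogen on an aromatic carbon of a six-membered aromatic ring of carbon only, ortho to a large group and meta to a hydroxymethyl group. Going by the values given here, no measured step touches this ring, so the measured steps bear only indirectly on it; they show that this assay can move strongly with a single small change, but give no direction for this one. The expected step is therefore a number 0.13 log units higher from compound 1 to compound 4 (within the scatter), not beyond the scatter. Compound 4 is estimated at 4.1, with a range from 3.5 to 4.7.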

Compound 4, negative logarithm of the antagonist equilibrium constant: 4.45
Compound 4: the middle estimate sits 0.35 log units below what was measured, and the stated range covers the measured number.
By their numbers in this assay, from the lowest: compound 1; then compound 4; then compounds 2 and 3 (each within the scatter of the next).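

Fluoro in place of hydrogen gives a number 0.48 log units higher from compound 1 to compound 4 (beyond the scatter) in this assay, so the aromatic ring carrying the hydroxymethyl group also responds to substitution, and even a single fluorine on it moves the number beyond the scatter. The earlier steps shown here showed this sensitivity only on the ring carrying the benzylamine, where the steps were large; this one is modest. Nothing measured here explains the rise.

Still open, from the compounds shown here alone, is whether the gain belongs to fluoro itself or would also appear with a chloro, methyl or methoxy group at the same place. Going by these compounds, it is also open whether this fluoro would add to the trifluoromethyl of compound 2 or the cyclopropyloxy of compound 3, giving a further rise when the two changes are combined.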